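A few compounds are considered here, and "the series" means these few. Any claim that something is new, unique, unknown or untested is made for them only; others in the source may bear on it.

Compound 1 `COc1ccc(/C=C/c2cc(OC)cc(OC)c2/C=C/C(=O)c2cccc(Br)c2)cc1` gives 5.1 ug/mL
Compound 2 `COc1ccc(/C=C/c2cc(OC)cc(OC)c2/C=C/C(=O)c2ccc(C)c(C)c2)cc1` gives 1.4 ug/mL

Among the compounds with values here, in a functional assay on B16-F10 cells (Mus musculus) for antiproliferative activity, read by MTT assay, with a stated time of 48 h (on this read-out lower numbers stand for stronger inhibition and higher numbers for weaker inhibition), compound 2 gives 1.4 ug/mL, the lower of the two numbers so far and so the stronger inhibition. The next compound, compound 3 `COc1ccc(/C=C/c2cc(OC)cc(OC)c2/C=C/C(=O)c2ccc(-c3ccccc3)cc2)cc1`, keeps the shared core and changes only the group on a carbonyl carbon, with 4-phenylphenyl in place of 3,4-dimethylphenyl on a carbonyl carbon. Within the data shown here, one measured step bears on this, a 3.6-fold lower number from compound 1 to compound 2 (0.56 log units; beyond the scatter), a modest change at that same place. Among the measured compounds shown here, it shows that swapping this group can move the number, but no measured compound carries 4-phenylphenyl, so the direction stays uncertain. A change of similar or smaller size is therefore expected, leaning towards a higher number, since compound 2 is the better of only two. The expected step is a 1.8-fold higher number from compound 2 to compound 3 (0.25 log units; within the scatter). For compound 3 the estimate is 2.5 ug/mL, with an expected range from 0.8 ug/mL to 8 ug/mL.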

Compound 3, half-maximal inhibitory concentration: 10.6 ug/mL
Beside the measured number, compound 3's estimate is 4.2-fold (0.63 log units) below it, outside the stated range (above it).
By their numbers in this assay, from the lowest: compound 2; then compound 1; then compound 3.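

In this assay, within the data shown here, the group on the carbonyl carbon matters more than the first pair suggested: moving to 4-phenylphenyl gives a 7.6-fold higher number from compound 2 to compound 3 (0.88 log units; beyond the scatter) and the largest step seen at this place so far. The same group also gives a 2.1-fold higher number from compound 1 to compound 3 (0.32 log units; beyond the scatter) so it ranks behind both single-ring groups, 3,4-dimethylphenyl and 3-bromophenyl, and a second aromatic ring goes with weaker inhibition in these three compounds, though a single example cannot make this a general rule. Nothing available here explains why this change weakens inhibition.

The compounds shown leave open whether a phenyl ring carrying an amine or a carboxylic acid would match or beat 3,4-dimethylphenyl at this place. They also leave open how a two-ring group joined in another way, such as naphthyl, would compare with 4-phenylphenyl.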